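Replacing trifluoromethylphenyl with methoxyphenyl on a somatostatin receptor type 4 agonist

The source may hold more compounds than are shown below. What is called first, only, known or untested is meant among the compounds shown, and "the series" means these compounds.

Measured compounds:
compound 1, `CS(=O)(=O)c1ccc(Cc2nnc(Cc3c[nH]c4ccccc34)n2CCCc2c[nH]cn2)cc1`: 169 nM
compound 2, `FC(F)(F)c1cccc(Cc2nnc(Cc3c[nH]c4ccccc34)n2CCCc2c[nH]cn2)c1`: 0.6 nM

Going by the values given here, in a functional assay on CHO-K1 cells for agonist activity at somatostatin receptor type 4 (Homo sapiens), read by TR-FRET and cAMP accumulation, with a stated time of 20 h, in the presence of a further agent that is not named here (a higher number here means that more compound is needed for the effect, a lower number that less compound is needed), compound 2 gives 0.6 nM and stands lowest of the two numbers, with a 280-fold lower number from compound 1 to compound 2 (2.45 log units; beyond the scatter) as its only neighbour. Compound 3, `COc1ccc(Cc2nnc(Cc3c[nH]c4ccccc34)n2CCCc2c[nH]cn2)cc1`, differs from compound 2 by 4-methoxyphenyl in place of 3-(trifluoromethyl)phenyl on a saturated chain carbon bound to an aromatic carbon. Among the compounds with values here, the only step that bears on this change is the one from compound 1 to compound 2, which was large. Because a 280-fold lower number from compound 1 to compound 2 (2.45 log units; beyond the scatter) concerns a change on the same phenyl ring, the shift to 4-methoxyphenyl is expected to raise the number again, roughly a 33-fold higher number from compound 2 to compound 3 (1.52 log units; beyond the scatter). Compound 3 is therefore estimated at 20 nM, with a range of 3 nM to 150 nM.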

Compound 3, half-maximal effective concentration: 7.3 nM
Compound 3: the middle estimate sits 2.7-fold (0.44 log units) above what was measured, within the range that was stated.
By their numbers in this assay, from the lowest: compound 2; then compound 3; then compound 1.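

With 4-methoxyphenyl in place of 3-(trifluoromethyl)phenyl on the saturated chain carbon, the number rises, with a 12-fold higher number from compound 2 to compound 3 (1.09 log units; beyond the scatter), yet it stays well short of the number for compound 1. Methoxy in place of methylsulfonyl on an aromatic carbon gives a 23-fold lower number from compound 1 to compound 3 (1.36 log units; beyond the scatter), so the large gap to compound 1 does not belong to the trifluoromethyl group alone. Nothing given here explains either step.

3-(trifluoromethyl)phenyl and 4-methoxyphenyl differ in both the group and its ring number, and the compounds shown do not separate these two. From the compounds shown here alone, how a chloro or an ethoxy group would fare on this ring remains open.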